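A few compounds are considered here, and "the series" means these few. Any claim that something is new, unique, unknown or untested is made for them only; others in the source may bear on it.

Two compounds share one core and differ only in the group at the end of the phenyl ring. Compound 1 `COc1ccc(C(=O)/C=C/c2cc3ccccc3[nH]c2=O)cc1` carries a methoxy group there; in a functional assay on NCI/ADR-RES cells (Homo sapiens) for cytotoxicity, read by sulforhodamine B assay, with a stated time of 24 h (on this read-out lower numbers stand for stronger inhibition of growth and higher numbers for weaker inhibition of growth), compound 1 gives 2630 nM. Compound 2 `O=C(/C=C/c1cc2ccccc2[nH]c1=O)c1ccc(O)cc1` carries a hydroxy group instead, and in this assay compound 2 gives 2900 nM. The step of a 1.1-fold higher number from compound 1 to compound 2 (0.04 log units; within the scatter) shows that this exchange left the read-out essentially unchanged. Of the two numbers measured, compound 2 stands at the higher one, with compound 1 the nearest and within the scatter of it, so neither can be called the stronger.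

Compound 3 `O=C(/C=C/c1cc2ccccc2[nH]c1=O)c1ccc(Cl)cc1` has not yet been measured. It differs from compound 2 by chloro in place of hydroxy on an aromatic carbon, on an aromatic carbon of a six-membered aromatic ring of carbon only, para to a large group; cut one bond further out, the change reads 4-hydroxyphenyl to 4-chlorophenyl. Within the data shown here, the one measured step at this position, a 1.1-fold higher number from compound 1 to compound 2 (0.04 log units; within the scatter), stayed within the scatter, though it swapped two oxygen-bearing groups rather than bringing in chlorine, so the expected step of a 1.2-fold lower number from compound 2 to compound 3 (0.06 log units; within the scatter) in this assay is small, with no firm direction. Compound 3 is therefore estimated at 2500 nM, in the range from 1000 nM to 6500 nM.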

Compound 3, concentration for 50% growth inhibition: 4000 nM
For compound 3 the middle estimate is 1.6-fold (0.20 log units) below the measured one; low and high end bracket the measured number.
By their numbers in this assay, from the lowest: compounds 1, 2 and 3 (each within the scatter of the next).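

The group at the end of the phenyl ring now carries no oxygen at all, and in this assay the exchange of hydroxy for chloro gives a 1.4-fold higher number from compound 2 to compound 3 (0.14 log units; within the scatter) and the exchange of methoxy for chloro gives a 1.5-fold higher number from compound 1 to compound 3 (0.18 log units; within the scatter) at this same place. All three compounds therefore lie within the scatter of one another, even though the chloro group brings 0 hydrogen-bond donors and 0 hydrogen-bond acceptors where the hydroxy group brought 1 of each, so in these compounds that count does not separate the numbers. Nothing available here bears on what lies behind this flat picture.

Going by these compounds, what remains open is whether any group on this aromatic carbon, para to a large group, can move the number beyond the scatter, and an amine, a carboxylic acid or a longer chain such as butoxy would each put that to a different test. The compounds shown also keep chloro, hydroxy and methoxy at this one place on an unchanged shared core, so how these groups behave elsewhere on the ring stays unknown.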